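The source may hold more compounds than are shown below. What is called first, only, known or untested is meant among the compounds shown, and "the series" means these compounds.

Compound 3, `COC(=O)N1CCC(Oc2ncnc3c2CCN3c2ccc(S(C)(=O)=O)cc2F)CC1`, is one of three compounds with a number in a functional assay on CHO-K1 cells for agonist activity at Glucose-dependent insulinotropic receptor (Homo sapiens), read by a luciferase reporter, with a stated time of 5 h; a higher number here means that more compound is needed for the effect, a lower number that less compound is needed. In this assay compound 3 gives 316 nM, the second highest of the three values. Its nearest neighbour is compound 1, `CC(C)(C)OC(=O)N1CCC(Oc2cccc3c2ccn3-c2ccc(S(C)(=O)=O)cc2)CC1`, which in this assay gives 631 nM; the two numbers lie within the scatter of each other, so nothing separates them. Its furthest neighbour is compound 2, `CC(C)OC(=O)N1CCC(Oc2ncnc3c2CCN3c2ccc(-c3nccs3)cc2F)CC1`, which in this assay gives 79.4 nM, a number that stands apart from compound 3 beyond the scatter. Compound 4, `CS(=O)(=O)c1ccc(N2CCc3c(OC4CCN(C(=S)Sc5ccccc5)CC4)ncnc32)c(F)c1`, has not yet been measured in this assay. It differs from compound 3 in one place: a group of 9 heavy atoms (7 carbon, 2 sulfur; one six-membered aromatic ring of carbon only) in place of a group of 4 heavy atoms (2 carbon, 2 oxygen; no ring), on an amine nitrogen in a ring. Going by the values given here, no step between two measured compounds changes this position alone, so the size of the step cannot be read from the measured pairs. Compound 4 is expected to give 630 nM, with a range from 160 nM to 2500 nM. The step this estimate means, a 2.0-fold higher number from compound 3 to compound 4 (0.30 log units; within the scatter), is expected to be a modest move toward a higher number, scarcely beyond the scatter.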

Compound 4, half-maximal effective concentration: 12.6 nM
The estimate for compound 4 lay 50-fold (1.70 log units) above the measured number, and the stated range ends above it.
By their numbers in this assay, from the lowest: compound 4; then compound 2; then compounds 3 and 1 (each within the scatter of the next).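

In this assay, the group on the amine nitrogen in the ring proves able to shift the number strongly: the group of 9 heavy atoms, with its six-membered aromatic ring of carbon only and its two sulfur atoms, replacing methoxycarbonyl gives a 25-fold lower number from compound 3 to compound 4 (1.40 log units; beyond the scatter). Going by these compounds alone, this is the first readable step at this position, and it comes with no change in the counts of hydrogen-bond donors, hydrogen-bond acceptors or double bonds outside aromatic rings. Nothing measured here explains why the number falls so far.

Size, the aromatic ring and the sulfur atoms all change in this one step, so the compounds shown do not tell which of them matters. A phenoxycarbonyl group, with oxygen in place of both sulfur atoms, would separate the contribution of the sulfur from that of the ring.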